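The source may report more compounds than this note shows. Statements on the series, on what has been measured and on what is new or still open speak of the compounds shown alone.

Measured compounds
Compound 1 (`O=C(CCCCCCNC(=O)C(O)(O)C(F)(F)F)Nc1nc2ccccc2o1`) reads 3450 nM
Compound 2 (`O=C(CCCCCCNC(=O)C(O)(O)C(F)(F)F)Nc1ccc(Br)cc1`) reads 3130 nM

In a functional assay on HCT-116 cells (Homo sapiens) for inhibition, read by colorimetric assay, with a stated time of 3 days (a lower number here means a stronger inhibitor, a higher number a weaker inhibitor), compound 1 gives 3450 nM and compound 2 gives 3130 nM so these two readings lie within the scatter of each other and cannot be told apart. For the measured compounds named here, compound 2 therefore stands level with the only other measured compound.

Compound 3 (`O=C(CCCCCCNC(=O)C(O)(O)C(F)(F)F)Nc1c(F)cc(F)cc1F`) has not yet been measured. Its structure departs from compound 2 in one place: 2,4,6-trifluorophenyl in place of 4-bromophenyl on an amide-type nitrogen which puts 2,4,6-trifluorophenyl in place of 4-bromophenyl on an amide-type nitrogen.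

Going by the values given here, only one measured step bears on this change, since it concerns the same nitrogen. That step is a 1.1-fold lower number from compound 1 to compound 2 (0.04 log units; within the scatter) and it shows that swapping one group there for a quite different one left the reading unchanged within the scatter. Among the compounds with values here, a single step is thin evidence, and no compound carrying 2,4,6-trifluorophenyl has been tested. Even so, no step beyond the scatter is expected in this assay in either direction.

The estimated change is a 1.0-fold higher number from compound 2 to compound 3 (0.01 log units; within the scatter) and it is expected to be small. For compound 3 the expected value is 3200 nM with an estimated range from 1300 nM to 8000 nM for repeated measurements.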

Compound 3, half-maximal inhibitory concentration: 22200 nM
The estimate for compound 3 lay 6.9-fold (0.84 log units) below the measured number, outside the stated range (above it).
By their numbers in this assay, from the lowest: compounds 2 and 1 (each within the scatter of the next); then compound 3.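

In this assay the group on the amide-type nitrogen turns out to matter, since 2,4,6-trifluorophenyl gives a 7.1-fold higher number from compound 2 to compound 3 (0.85 log units; beyond the scatter) and a 6.4-fold higher number from compound 1 to compound 3 (0.81 log units; beyond the scatter), which makes compound 3 the weakest inhibitor of the three. The earlier pair hinted at a position indifferent to its group, with a 1.1-fold lower number from compound 1 to compound 2 (0.04 log units; within the scatter), but that held only for 1,3-benzoxazol-2-yl and 4-bromophenyl, so two very different groups can read alike here while a third, also a six-membered aromatic ring of carbon only, does not. No measurement in hand accounts for the loss seen with 2,4,6-trifluorophenyl.

The compounds shown leave open whether the step depends on the number of fluorine atoms, on where they sit on the ring, or on the loss of the bromine, and a plain phenyl ring or a phenyl ring carrying a single fluorine would help to separate these possibilities. They also leave open whether the same step would appear with a shorter or longer chain between the two amide groups.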